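Swapping a Ring Carbon for Sulfur: Solubility Outlook

The compounds below may be only part of what the source reports. "The series", "measured", "known", "first", "only" and "open" are said of these compounds alone.

Compound 1, `O=C1O[C@@H](CN2CCCCC2)CN1c1ccc(-n2cc(-c3ccccn3)cn2)c(F)c1`: 219000 nM
Compound 2, `O=C1CCC(=O)N1C[C@H]1CN(c2ccc(-n3cc(-c4ccccn4)cn3)c(F)c2)C(=O)O1`: 45300 nM

In a physicochemical assay for solubility, read by HPLC, with a stated time of 24 h (on this read-out lower numbers stand for lower solubility and higher numbers for higher solubility), compound 2 gives 45300 nM, the lowest of the two numbers. Compound 1 gives 219000 nM, and the difference shows a 4.8-fold lower number from compound 1 to compound 2 (0.68 log units; beyond the scatter). Compound 3, `O=C1CSC(=O)N1C[C@H]1CN(c2ccc(-n3cc(-c4ccccn4)cn3)c(F)c2)C(=O)O1`, has not been measured; it differs from compound 2 by 2,4-dioxo-1,3-thiazolidin-3-yl in place of 2,5-dioxopyrrolidin-1-yl on a saturated chain carbon bound to a saturated ring carbon. Going by the values given here, no measured step covers this exchange: the only measured step, a 4.8-fold lower number from compound 1 to compound 2 (0.68 log units; beyond the scatter), concerns a different group. The expected change is therefore a 1.0-fold lower number from compound 2 to compound 3 (0.00 log units; within the scatter), none beyond the scatter. Compound 3 is estimated at 45000 nM in this assay, with a range from 15000 nM to 130000 nM.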

Compound 3, solubility: 26900 nM
Compound 3: middle estimate off by 1.7-fold (0.22 log units), on the high side, and the stated range covers the measured number.
By their numbers in this assay, from the lowest: compounds 3 and 2 (each within the scatter of the next); then compound 1.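

Exchanging 2,5-dioxopyrrolidin-1-yl for 2,4-dioxo-1,3-thiazolidin-3-yl on this chain carbon gives a 1.7-fold lower number from compound 2 to compound 3 (0.23 log units; within the scatter) in this assay and so stays within the scatter. Exchanging piperidin-1-yl for the same sulfur ring gives an 8.1-fold lower number from compound 1 to compound 3 (0.91 log units; beyond the scatter) and lies beyond it, so both dione rings stand well apart from piperidin-1-yl. No measurement shown here accounts for either step. As far as these compounds go, whether a morpholine ring or an open-chain amide on the same carbon would fall nearer piperidin-1-yl or the dione rings remains open. So does whether these steps would hold on a different core.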